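A few compounds are considered here, and "the series" means these few. Any claim that something is new, unique, unknown or untested is made for them only; others in the source may bear on it.

Measured compounds:
compound 1 `O=S(=O)(Nc1ccc2oc(-c3ccccc3)nc2c1)c1cccc(F)c1` — 68000 nM
compound 2 `O=S(=O)(Nc1ccc2oc(-c3ccccc3)nc2c1)c1ccc(Cl)c(C(F)(F)F)c1` — 66000 nM

The study measures how much of each compound HEK293 cells tolerate, in an ADME assay on HEK293 cells (Homo sapiens) for cytotoxicity, read by resazurin assay, with a stated time of 48 h; a higher number here means that more compound is tolerated, a lower number that less compound is tolerated. In this assay compound 1 gives 68000 nM, and compound 2 gives 66000 nM. The two numbers lie within the scatter of each other, so nothing separates compound 1 from compound 2 here; both are tolerated at a high concentration, and compound 1 stands at the top only by a margin that means nothing.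

The next compound is compound 3 `O=S(=O)(Nc1ccc2oc(-c3ccccc3)nc2c1)c1cccs1`, which keeps the shared core and the sulfonamide of compound 1 but differs in one place: thiophen-2-yl in place of 3-fluorophenyl on a sulfonyl sulfur. Among the compounds with values here, no measured pair shows what this kind of exchange does in this assay, so the expectation rests on the two numbers above, which sit close together despite different groups on the sulfonyl sulfur. The step from compound 1 to compound 3 is therefore expected to be small, a 1.0-fold lower number from compound 1 to compound 3 (0.02 log units; within the scatter), in no particular direction beyond the scatter. Compound 3 is expected to give about 65000 nM, within a range from 30000 nM to 140000 nM.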

Compound 3, half-maximal cytotoxic concentration: 97000 nM
The estimate for compound 3 lay 1.5-fold (0.17 log units) below the measured number; measured number inside the range.
By their numbers in this assay, from the lowest: compounds 2, 1 and 3 (each within the scatter of the next).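

In this assay, within the data shown here, the exchange of 3-fluorophenyl for thiophen-2-yl on a sulfonyl sulfur gives the first single-place comparison at this position, a 1.4-fold higher number from compound 1 to compound 3 (0.15 log units; within the scatter) and this step lies within the scatter. At this place, then, a five-membered aromatic ring with 1 hetero atom can stand where a six-membered aromatic ring of carbon only stood without a difference that this read-out can separate from repeated measurement, and compound 3, like compound 1, is tolerated at a high concentration. Nothing measured here offers an explanation for the step, and this one pair cannot show whether it is more than scatter.

The compounds shown leave open whether a group on the sulfonyl sulfur that is not an aromatic ring, such as a methyl group, a longer alkyl chain or a morpholine, would give a number beyond the scatter of compound 1. They also leave open whether an amine or a carboxylic acid placed elsewhere on the shared core would change how much compound the cells tolerate.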